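The source may report more compounds than this note shows. Statements on the series, on what has been measured and on what is new or still open speak of the compounds shown alone.

Compound 1 `COc1cc(C)cc(-c2c(-c3ccnc(-c4ccc(C(C)=O)cc4)c3)cnn2CC#N)c1`: in a functional assay on OVCAR-3 cells (Homo sapiens) for inhibition, read by sulforhodamine B assay, with a stated time of 48 h (on this read-out lower numbers stand for higher toxicity in this test and higher numbers for lower toxicity in this test), compound 1 gives > 100000 nM, which is a limit of the assay rather than a number.
Compound 2 `Cc1cc(O)cc(-c2nn(CC#N)cc2-c2ccnc(-c3ccc(Oc4ccccc4)cc3)c2)c1`: in this assay compound 2 gives 8290 nM.
Compound 3 `Cc1cc(O)cc(-c2nn(CC#N)cc2-c2ccnc(-c3ccc(N(C)C)cc3)c2)c1`: in this assay compound 3 gives 21200 nM.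

Compound 1 stands at the limit of > 100000 nM in this assay, at which 1 of the 3 values shown sits, so only a range is known for it. The change to compound 4 `COc1cc(C)cc(-c2c(-c3ccnc(-c4ccc(N(C)C)cc4)c3)cnn2CC#N)c1` is dimethylamino in place of acetyl on an aromatic carbon. Among the measured compounds shown here, no measured step exchanges acetyl for dimethylamino, but the step of a 2.6-fold higher number from compound 2 to compound 3 (0.41 log units; beyond the scatter) brings in the same dimethylamino group at the same place in the shared core, and it gave only a modest rise in the number. Because compound 1 already sits at the limit of > 100000 nM in this assay, at which 1 of the 3 values shown sits, a step of that size in either direction would probably leave compound 4 at the limit once more. Compound 4 is therefore expected to show 100000 nM, within 30000 nM to 300000 nM, an estimated step of a number no higher from compound 1 to compound 4 (the limit leaves the size open).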

Compound 4, concentration lethal to 50% of the cells: > 100000 nM
Compound 4 gave a limit, no number; the forecaster's own chance of this, stated with the estimate: 60%; the middle value sits exactly at the limit.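

Compound 1 and compound 4 both stand at a limit of this assay rather than at a number, so no step can be read between them: the limit of > 100000 nM in this assay, at which 2 of the 4 values shown sit.

On these data alone, what stays open is whether dimethylamino in place of acetyl changes the result in this assay at all, and by how much.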